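The source may report more compounds than this note shows. Statements on the series, on what has been measured and on what is new or still open speak of the compounds shown alone.

- compound 1 `C[C@]1(c2cc(NC(=O)c3ccc(Cl)cn3)cc(F)c2F)N=C(N)S[C@H]2C[C@H]21`: 13 10^-6 cm/s
- compound 2 `COC[C@]12C[C@H]1[C@@](C)(c1cc(NC(=O)c3ccc(Cl)cn3)cc(F)c1F)N=C(N)S2`: 13 10^-6 cm/s

In an ADME assay on LLC-PK1 cells (Sus scrofa) for permeability (on this read-out higher numbers stand for higher permeability and lower numbers for lower permeability), compound 2 reads 13 10^-6 cm/s and compound 1 reads 13 10^-6 cm/s, so the two stand level, within the usual scatter. The next compound, compound 3 `C[C@]1(c2cc(NC(=O)c3ccc(Cl)cn3)cc(F)c2F)N=C(N)S[C@@]2(C(N)=O)C[C@H]21`, has carbamoyl in place of methoxymethyl on a saturated ring carbon. Among the measured compounds shown here, no measured pair shows this exchange, so the expectation rests on the structural change alone. A clear fall in this assay, beyond the scatter, is expected, an estimated step of a 2.6-fold lower number from compound 2 to compound 3 (0.41 log units; beyond the scatter). For compound 3 the estimate is 5 10^-6 cm/s, with a range of 2 10^-6 cm/s to 10 10^-6 cm/s.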

Compound 3, apparent permeability: 38 10^-6 cm/s
Beside the measured number, compound 3's estimate is 7.6-fold (0.88 log units) below it; the measured number lies above the stated range.
By their numbers in this assay, from the lowest: compounds 1 and 2 (each within the scatter of the next); then compound 3.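

On a saturated ring carbon of the three-membered ring, carbamoyl in place of methoxymethyl gives, in this assay, a 2.9-fold higher number from compound 2 to compound 3 (0.47 log units; beyond the scatter), a step beyond the scatter. The number at this position therefore moves with the group placed there, and the hydrogen-bond donor that carbamoyl brings and methoxymethyl lacks comes with a higher reading, not a lower one. Nothing at hand gives a reason for this rise. As far as these compounds go, whether the donor or the carbamoyl group as a whole matters stays open, as does what an amine or a carboxylic acid on the same carbon would read.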